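A few compounds are considered here, and "the series" means these few. Any claim that something is new, unique, unknown or untested is made for them only; others in the source may bear on it.

Measured so far in an assay on isolated protein for activation of cGMP-dependent protein kinase 1 (Homo sapiens), read by ADP-Glo, with stated times of 30 min and 2 h, in the presence of a further agent that is not named here; on this read-out higher numbers stand for an effect only at larger amounts of compound and lower numbers for an effect already at smaller amounts:
compound 1 `Cc1cc(C(=O)O)ccc1CN1CCC[C@H](O[C@H](CO)c2cc(Cl)cc(Cl)c2)[C@@H]1c1cccnc1` — 47000 nM
compound 2 `Cc1cc(C(=O)O)ccc1CN1CCC[C@H](O[C@H](CO)c2cc(Cl)cc(Cl)c2)[C@@H]1C1CCCCC1` — 65000 nM

Among the compounds with values here, compound 2 stands at the higher of the two numbers in this assay; its only neighbour is compound 1, and the step of a 1.4-fold higher number from compound 1 to compound 2 (0.14 log units; within the scatter) is within the scatter, so the two are not separable on these data.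

Compound 3 `Cc1cc(C(=O)O)ccc1CN1CCC[C@H](O[C@H](CO)c2cc(Cl)cc(Cl)c2)[C@@H]1c1ccccc1F` differs from compound 2 in one place: 2-fluorophenyl in place of cyclohexyl on a saturated ring carbon. Within the data shown here, the single measured step that bears on this change is a 1.4-fold higher number from compound 1 to compound 2 (0.14 log units; within the scatter), where an aromatic pyridin-3-yl and a non-aromatic cyclohexyl on the same saturated ring carbon gave numbers within the scatter of each other. Among the measured compounds shown here, compound 3 again carries an aromatic six-membered ring on that saturated ring carbon; with only this one step as precedent, no step beyond the scatter is expected in this assay, a 1.3-fold lower number from compound 2 to compound 3 (0.11 log units; within the scatter). Compound 3 is therefore estimated at 50000 nM, with a range from 18000 nM to 140000 nM.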

Compound 3, half-maximal effective concentration: 2600 nM
Beside the measured number, compound 3's estimate is 19-fold (1.28 log units) above it, outside the stated range (below it).
By their numbers in this assay, from the lowest: compound 3; then compounds 1 and 2 (each within the scatter of the next).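

In this assay, the saturated ring carbon next to the ring nitrogen proves sensitive to the group it carries: 2-fluorophenyl in place of cyclohexyl gives a 25-fold lower number from compound 2 to compound 3 (1.40 log units; beyond the scatter) on this series, and 2-fluorophenyl in place of pyridin-3-yl gives an 18-fold lower number from compound 1 to compound 3 (1.26 log units; beyond the scatter) as well. An aromatic six-membered ring alone does not account for this pattern, since compound 1 also carries one and stays within the scatter of compound 2, so this position separates two aromatic groups that the earlier pair gave no sign of separating. Nothing available here explains the step.

Open, on these data alone, is whether a plain phenyl group would read with compound 3 or with compound 1 and compound 2, which would separate the ring from its fluorine. Also open, as far as these compounds go, is how a methoxy or trifluoromethyl group in place of that fluorine would read.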